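A few compounds are considered here, and "the series" means these few. Any claim that something is new, unique, unknown or untested is made for them only; others in the source may bear on it.

Compound 1 `CSc1ccc(C)cc1NCC1=NCCN1` gives 0.912 nM in a functional assay for agonist activity at Alpha-1D adrenergic receptor (Homo sapiens); on this read-out lower numbers stand for an effect already at smaller amounts and higher numbers for an effect only at larger amounts of compound. Compound 2 `CS(=O)(=O)c1ccc(F)cc1NCC1=NCCN1` shows in this assay only a limit, < 100000 nM, as noted in the limit of < 100000 nM in this assay, at which 1 of the 2 values shown sits, and not a number. Compound 3 `Cc1ccc(S(C)(=O)=O)c(NCC2=NCCN2)c1` has not yet been measured. It differs from compound 2 by methyl in place of fluoro on an aromatic carbon. Among the compounds with values here, with compound 2 known only as a limit, no step between measured compounds tells how large this change usually is. Compound 3 is expected to give 1000 nM, with a range from 10 nM to 100000 nM. The step this expectation means is a step that the limit leaves unreadable from compound 2 to compound 3, which could be anything from none beyond the scatter to a large gain.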

Compound 3, half-maximal effective concentration: < 2000 nM
Compound 3: a limit, no number (the forecaster's own chance of this, stated with the estimate: 30%); the middle value is on the limit's open side.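

No size can be read for the steps from compound 2 to compound 3 or from compound 1 to compound 3, as compound 2 and compound 3 each stand only as a limit. Going by these compounds, what methyl in place of fluoro, or methylsulfonyl in place of methylsulfanyl, does to the measured value stays open.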